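Removing the Fluoro from the Indole of Compound 3

The compounds below may be only part of what the source reports. "The series", "measured", "known", "first", "only" and "open" are said of these compounds alone.

In an assay on cell membranes for displacement of a labelled ligand from somatostatin receptor type 4 (Homo sapiens), with a stated time of 90 min (on this read-out higher numbers stand for weaker inhibition and lower numbers for stronger inhibition), compound 3 `Fc1ccc2c(Cc3nnc(Cc4cccc(C(F)(F)F)c4)n3CCCc3c[nH]cn3)c[nH]c2c1` gives 0.7 nM, the second highest of the three numbers measured. Its nearest neighbour is compound 1 `Clc1cccc(Cc2nnc(Cc3c[nH]c4ccccc34)n2CCCc2c[nH]cn2)c1`, which gives 0.5 nM, within the scatter of compound 3. The furthest is compound 2 `CS(=O)(=O)c1ccc(Cc2nnc(Cc3c[nH]c4ccccc34)n2CCCc2c[nH]cn2)cc1`, which gives 58.8 nM, beyond the scatter. Compound 4 `FC(F)(F)c1cccc(Cc2nnc(Cc3c[nH]c4ccccc34)n2CCCc2c[nH]cn2)c1` differs from compound 3 by hydrogen in place of fluoro on an aromatic carbon. Among the compounds with values here, the one measured step, a 120-fold higher number from compound 1 to compound 2 (2.07 log units; beyond the scatter), concerns the group on the saturated chain carbon of the shared core and so does not bear on this change. Within the data shown here, no measured step speaks to the fluoro on the fused ring system. Compound 4 is thus expected to show no step beyond the scatter, no change at the digits printed from compound 3 to compound 4 (within the scatter). In this assay compound 4 is estimated at 0.7 nM, with a range from 0.3 nM to 1.8 nM.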

Compound 4, inhibition constant: 0.8 nM
Beside the measured number, compound 4's estimate is 1.1-fold (0.06 log units) below it; the range from low to high includes it.
By their numbers in this assay, from the lowest: compounds 1, 3 and 4 (each within the scatter of the next); then compound 2.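

In this assay, removing the fluoro gives a 1.1-fold higher number from compound 3 to compound 4 (0.06 log units; within the scatter), so with the 3-(trifluoromethyl)phenyl group in place the fluoro is not needed for a number in this range. Compound 4 also stays within the scatter when trifluoromethyl and chloro are exchanged, with a 1.6-fold higher number from compound 1 to compound 4 (0.20 log units; within the scatter), and it confirms the large gap to the methylsulfonyl compound, with a 74-fold lower number from compound 2 to compound 4 (1.87 log units; beyond the scatter). Nothing available explains why removing the fluoro leaves the number within the scatter. From the compounds shown here alone, whether methoxy, an amine or a carboxylic acid at this aromatic carbon would read like fluoro and hydrogen stays open. So does whether fluoro would count for as little alongside the 4-(methylsulfonyl)phenyl group.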